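Removing the methyl from compound 1: expected outcome

The source may hold more compounds than are shown below. What is called first, only, known or untested is meant among the compounds shown, and "the series" means these compounds.

Compound 1 `Cc1ccc2[nH]c(=O)c(-c3nc4cc(Cl)ccc4[nH]3)cc2c1` is the reference point of this pair. Within the data shown here, in a functional assay on HepG2 cells (Homo sapiens) for cytotoxicity, read by MTT assay, with a stated time of 48 h (a higher number here means a weaker inhibitor, a lower number a stronger inhibitor), compound 1 gives 26600 nM, the only number so far in the set. Compound 2 `Cc1ccc2[nH]c(=O)c(-c3nc4cc(Br)ccc4[nH]3)cc2c1` sits at the limit of > 100000 nM in this assay, at which 1 of the 2 values shown sits. In this assay compound 2 gives > 100000 nM, a limit rather than a number. Among the measured compounds shown here, the step of an at least 3.7-fold higher number from compound 1 to compound 2 (0.57 log units; beyond the scatter) is the single measured comparison, and it concerns the halogen alone, not the methyl.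

Compound 3 `O=c1[nH]c2ccccc2cc1-c1nc2cc(Cl)ccc2[nH]1` differs from compound 1 by hydrogen in place of methyl on an aromatic carbon. No measured step touches this position, so nothing among the shown compounds points to a move in either direction. The step expected in this assay is therefore no change at the digits printed from compound 1 to compound 3 (within the scatter), nothing beyond the scatter. Compound 3 is estimated at 26600 nM, with a range from 10000 nM to 70000 nM.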

Compound 3, half-maximal inhibitory concentration: 8450 nM
Compound 3: middle estimate off by 3.1-fold (0.50 log units), on the high side; the whole stated range lies above it.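

In this assay, this aromatic carbon proves to be a second place in the series where a single change moves the read-out, alongside the halogen: hydrogen in place of methyl gives a 3.1-fold lower number from compound 1 to compound 3 (0.50 log units; beyond the scatter). The methyl is therefore not required for the inhibition seen with compound 1, and the direction of the step favours the unsubstituted carbon for this pair, with chloro held constant. Nothing shown explains why the number falls on losing this one carbon.

Among these compounds, it remains open whether the same step holds with bromo in place of chloro, given that the only other measured compound, compound 2, carries the methyl. Also open, on these data alone, is how the read-out responds to other groups on this carbon, such as fluoro, methoxy, ethyl or an amine.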